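Plasma stability across carbonyl substituents on the shared core

This account rests on a few compounds, and the source may have more. Where it says the series, first, only, none or still open, it means among the compounds named here.

Three analogues of one core have been read in an ADME assay on a cell-free system (plasma, Homo sapiens) for metabolic stability, read by LC-MS, tested at 10 ug/mL; a higher number here means that the compound lasts longer, a lower number that the compound disappears faster. Compound 1 `COCCOC(=O)c1cc(N)c(Nc2ccc(C#N)cc2)cc1Oc1c(C)cc(/C=C/C#N)cc1C` gives 62 h, compound 2 `Cc1cc(/C=C/C#N)cc(C)c1Oc1cc(Nc2ccc(C#N)cc2)c(N)cc1C(N)=O` gives 65 h, and compound 3 `Cc1cc(/C=C/C#N)cc(C)c1Oc1cc(Nc2ccc(C#N)cc2)c(N)cc1C(=O)NCCC(F)F` gives 57 h, the lowest of the three, with compound 1 nearest and compound 2 furthest, both gaps within the scatter. Compound 4 `Cc1cc(/C=C/C#N)cc(C)c1Oc1cc(Nc2ccc(C#N)cc2)c(N)cc1C(=O)N1CC1` carries aziridin-1-yl in place of (3,3-difluoropropyl)amino on a carbonyl carbon. Among the measured compounds shown here, the steps that bear on this are the exchanges at the same carbonyl carbon, a 1.1-fold lower number from compound 1 to compound 3 (0.04 log units; within the scatter) and a 1.1-fold lower number from compound 2 to compound 3 (0.06 log units; within the scatter), neither beyond the scatter. Accordingly no step beyond the scatter is expected for a 1.0-fold higher number from compound 3 to compound 4 (0.01 log units; within the scatter). Compound 4 is estimated at 58 h in this assay, within 35 h to 95 h.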

Compound 4, half-life: 12 h
Compound 4: middle estimate off by 4.8-fold (0.68 log units), on the high side; measured number outside the range, below it.
By their numbers in this assay, from the lowest: compound 4; then compounds 3, 1 and 2 (each within the scatter of the next).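

In this assay this carbonyl carbon is not indifferent to its substituent: aziridin-1-yl gives a 4.8-fold lower number from compound 3 to compound 4 (0.68 log units; beyond the scatter) against (3,3-difluoropropyl)amino, a 5.4-fold lower number from compound 2 to compound 4 (0.73 log units; beyond the scatter) against amino, and a 5.2-fold lower number from compound 1 to compound 4 (0.71 log units; beyond the scatter) against 2-methoxyethoxy. The three earlier groups lie within the scatter of one another, so among these four compounds only aziridin-1-yl separates from the rest. Nothing measured here accounts for the step.

Still open, as far as these compounds go, is whether the three-membered ring itself carries the step, which dimethylamino or a larger saturated cyclic amine at the same carbonyl carbon would test.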